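The source may hold more compounds than are shown below. What is called first, only, known or untested is meant among the compounds shown, and "the series" means these compounds.

Compound 2 `COc1ccc(S(=O)(=O)N2CCN(c3ncc(/C=C/C(=O)NO)s3)CC2)cc1OC` carries a 3,4-dimethoxyphenyl on the sulfonyl sulfur. In a functional assay on MCF7 cells (Homo sapiens) for antiproliferative activity (on this read-out higher numbers stand for weaker inhibition of growth and lower numbers for stronger inhibition of growth), compound 2 gives 4000 nM, while compound 1 `O=C(/C=C/c1cnc(N2CCN(S(=O)(=O)c3ccc(C(F)(F)F)cc3)CC2)s1)NO` gives 3000 nM. These two numbers are all that is known so far, and they lie within the usual scatter of each other, as the step of a 1.3-fold higher number from compound 1 to compound 2 (0.12 log units; within the scatter) shows, so neither compound can be set apart from the other. Compound 3 `O=C(/C=C/c1cnc(N2CCN(S(=O)(=O)c3ccc(F)cc3)CC2)s1)NO` differs from compound 2 by 4-fluorophenyl in place of 3,4-dimethoxyphenyl on a sulfonyl sulfur. Among the compounds with values here, the only measured step that bears on this change is the earlier exchange of one aryl group for another on the same sulfonyl sulfur, a 1.3-fold higher number from compound 1 to compound 2 (0.12 log units; within the scatter), which stayed within the scatter. On that basis the expected step for compound 3 is a 1.1-fold lower number from compound 2 to compound 3 (0.06 log units; within the scatter), nothing beyond the scatter in either direction. For compound 3 the estimate is 3500 nM, with a range from 1500 nM to 8000 nM.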

Compound 3, concentration for 50% growth inhibition: 2500 nM
For compound 3 the middle estimate is 1.4-fold (0.15 log units) above the measured one; the measured number falls inside the stated range.
By their numbers in this assay, from the lowest: compounds 3, 1 and 2 (each within the scatter of the next).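

In this assay the exchange on the sulfonyl sulfur gives a 1.6-fold lower number from compound 2 to compound 3 (0.20 log units; within the scatter), and the exchange on the aromatic carbon gives a 1.2-fold lower number from compound 1 to compound 3 (0.08 log units; within the scatter); both steps stay within the scatter. With a third aryl group in hand, the three sulfonyl substituents still cannot be told apart, and this holds even between 3,4-dimethoxyphenyl, with its 2 hydrogen-bond acceptors, and 4-fluorophenyl, with 0. No measurement is available that would explain this result.

The compounds shown carry only substituted phenyl groups on the sulfonyl sulfur, so it remains open whether a methyl group, a longer alkyl chain or a phenyl ring bearing an amine or a carboxylic acid there would give a step beyond the scatter. Going by these compounds, it also remains open whether a carbonyl in place of the sulfonyl would do so.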